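Fluoro on the benzyl ring of compound 3

The source may report more compounds than this note shows. Statements on the series, on what has been measured and on what is new or still open speak of the compounds shown alone.

Among the compounds with values here, compound 3 `Cc1nn2c(N)nnc2cc1Cc1ccccc1` gives 22 mg/kg in a functional assay on the whole organism with Mus musculus as the target, in the maximal electroshock model (on this read-out higher numbers stand for an effect only at larger amounts of compound and lower numbers for an effect already at smaller amounts), the second highest of the three numbers measured so far. Compound 2 `Cc1nn2cnnc2cc1Cc1ccccc1` gives 9.5 mg/kg in this assay, and compound 1 `Cc1nn2c(-c3ccccc3)nnc2cc1Cc1ccccc1` gives 108 mg/kg. All three steps measured so far sit on one aromatic carbon of the shared core: an 11-fold lower number from compound 1 to compound 2 (1.06 log units; beyond the scatter), a 4.9-fold lower number from compound 1 to compound 3 (0.69 log units; beyond the scatter) and a 2.3-fold higher number from compound 2 to compound 3 (0.36 log units; beyond the scatter). Compound 4 `Cc1nn2c(N)nnc2cc1Cc1ccc(F)cc1` differs from compound 3 in a different place: fluoro in place of hydrogen on an aromatic carbon. Within the data shown here, none of the measured steps touches the benzyl ring, so no step bears directly on this change; the three numbers show only that the substituent on the core moves the dose in this assay by modest to large amounts, while the benzyl ring has stayed the same throughout. With nothing to point either way, the change from compound 3 to compound 4 is expected to give a step within the scatter, a 1.1-fold lower number from compound 3 to compound 4 (0.04 log units; within the scatter). Compound 4 is therefore estimated to give 20 mg/kg in this assay, with a range from 9 mg/kg to 45 mg/kg.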

Compound 4, dose for half-maximal effect: 43 mg/kg
For compound 4 the middle estimate is 2.2-fold (0.33 log units) below the measured one; the measured number falls inside the stated range.
By their numbers in this assay, from the lowest: compound 2; then compounds 3 and 4 (each within the scatter of the next); then compound 1.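

Fluoro in place of hydrogen on the benzyl ring, para to a large group, gives a 2.0-fold higher number from compound 3 to compound 4 (0.29 log units; within the scatter) in this assay, so compound 3 and compound 4 cannot be told apart on this read-out. Within the data shown here, this is the first step away from the substituent site on the shared core, and unlike the three steps there, all printed as beyond the scatter, it shows no change that can be read, though it rests on a single pair. No supporting data on the compounds bear on this result.

The compounds shown leave open whether a larger group on this carbon, such as chloro, methoxy or trifluoromethyl, would also stay within the scatter. They also leave open whether fluoro at the same place on compound 2, with hydrogen instead of amino on the core, would give a similar step.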